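Aryl amide swap within a series sitting at the assay limit

The source may report more compounds than this note shows. Statements on the series, on what has been measured and on what is new or still open speak of the compounds shown alone.

Three compounds share one core and differ only in the aryl group carried on the amide-type nitrogen. Compound 1 `C/C(=N\OCC(=O)Nc1cccc(F)c1)C1=C(O)c2ccccc2S(=O)(=O)N1C` carries a 3-fluorophenyl there; in a functional assay on THP-1 cells (Homo sapiens) for inhibition, read by ELISA, with stated times of 2 h and 48 h (on this read-out lower numbers stand for stronger inhibition and higher numbers for weaker inhibition), compound 1 gives > 20000 nM, which is a limit of the assay rather than a number. Compound 2 `COc1cccc(NC(=O)CO/N=C(\C)C2=C(O)c3ccccc3S(=O)(=O)N2C)c1` carries a 3-methoxyphenyl; in this assay compound 2 gives > 20000 nM, again a limit. Compound 3 `C/C(=N\OCC(=O)Nc1ccc(C(F)(F)F)cc1)C1=C(O)c2ccccc2S(=O)(=O)N1C` carries a 4-(trifluoromethyl)phenyl; in this assay compound 3 gives > 20000 nM, once more a limit. Compound 3 therefore stands exactly where every value shown sits, namely (the limit of > 20000 nM in this assay, at which 3 of the 3 values shown sit). The measured steps, a step that the two limits leave unreadable from compound 1 to compound 2, a step that the two limits leave unreadable from compound 1 to compound 3 and a step that the two limits leave unreadable from compound 2 to compound 3, carry no readable size.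

Compound 4 `C/C(=N\OCC(=O)Nc1ccc(F)c(Cl)c1)C1=C(O)c2ccccc2S(=O)(=O)N1C` differs from compound 3 by 3-chloro-4-fluorophenyl in place of 4-(trifluoromethyl)phenyl on an amide-type nitrogen. The three measured steps bear on it only in that each left the aryl group changed without moving the value off the limit, so no step beyond the scatter is expected in this assay; the expected step is a step that the limit leaves unreadable from compound 3 to compound 4. For compound 4 the estimated value is 30000 nM, with a range from 10000 nM to 100000 nM, and most likely only a limit will again be reported.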

Compound 4, half-maximal inhibitory concentration: > 20000 nM
Compound 4 ended at the assay's limit; the forecaster's own chance of this, stated with the estimate: 80%; the middle value lies beyond the limit too.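

Compound 4 also ends at a limit of the assay, so its steps from compound 1, compound 2 and compound 3 cannot be read: the limit of > 20000 nM in this assay, at which 4 of the 4 values shown sit. The compounds shown leave open how strongly any of these four inhibits, and whether any aryl group on the amide-type nitrogen gives a readable value.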